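This account rests on a few compounds, and the source may have more. Where it says the series, first, only, none or still open, it means among the compounds named here.

Compound 1 `N#Cc1ccc(N2CCN(C(=S)SCc3ccc(C(=O)Nc4ccccc4N)cc3)CC2)cc1`: 70.6%
Compound 2 `Nc1ccccc1NC(=O)c1ccc(CSC(=S)N2CCN(c3ncccn3)CC2)cc1`: 73.9%
Compound 3 `Nc1ccccc1NC(=O)c1ccc(CSC(=S)N2CCN(c3ccncc3)CC2)cc1`: 77.4%

In a functional assay on HeLa cells (Homo sapiens) for antiproliferative activity, read by CCK-8 assay, with a stated time of 72 h, tested at 8 uM (a lower number here means a weaker effect, a higher number a stronger effect of the compound at the concentration tested), compound 3 holds the highest of the three numbers shown, although the steps of a number 3.5 percentage points higher from compound 2 to compound 3 (within the scatter) and a number 6.8 percentage points higher from compound 1 to compound 3 (within the scatter) both lie within the scatter, so no real ordering among the three can be claimed. Compound 4 `Nc1ccccc1NC(=O)c1ccc(CSC(=S)N2CCN(C3CCCCC3)CC2)cc1` differs from compound 3 as cyclohexyl in place of pyridin-4-yl on an amine nitrogen in a ring. The measured steps that bear on this change all swap the group on the same ring nitrogen: a number 3.3 percentage points higher from compound 1 to compound 2 (within the scatter), a number 6.8 percentage points higher from compound 1 to compound 3 (within the scatter) and a number 3.5 percentage points higher from compound 2 to compound 3 (within the scatter), each within the scatter. None of them, however, brings in a ring that is not aromatic. The expected step of a number 5.4 percentage points lower from compound 3 to compound 4 (within the scatter) is therefore none beyond the scatter. Compound 4 is estimated at 72%, between 58% and 84%.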

Compound 4, a percentage reported as inhibition, at one concentration (the size of the read-out at that concentration, not a potency): 76.1%
Compound 4: the middle estimate sits 4.1 percentage points below what was measured; the range from low to high includes it.
By their numbers in this assay, from the lowest: compounds 1, 2, 4 and 3 (each within the scatter of the next).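

In this assay the cyclohexyl group, the first ring on this nitrogen that is not aromatic and the first of carbon only, stays within the scatter of all three aromatic groups: there is a number 1.3 percentage points lower from compound 3 to compound 4 (within the scatter) and a number 2.2 percentage points higher from compound 2 to compound 4 (within the scatter) and a number 5.5 percentage points higher from compound 1 to compound 4 (within the scatter) at this single concentration. Losing the hydrogen-bond acceptor of pyridin-4-yl thus brings no step beyond the scatter here. No measurement shown accounts for this result.

As far as these compounds go, whether a small methyl group, an open butyl chain or a carboxylic acid on this nitrogen would hold the read-out remains open. So does any ordering of these compounds by a stronger or weaker effect at this single concentration.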